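The source may hold more compounds than are shown below. What is called first, only, known or untested is meant among the compounds shown, and "the series" means these compounds.

In an assay on isolated protein for inhibition of E3 ubiquitin-protein ligase Mdm2 (Homo sapiens), read by fluorescence polarization, with a stated time of 30 min (a higher number here means a weaker inhibitor, a lower number a stronger inhibitor), compound 1 `CCOc1cc(C(C)(C)C)ccc1C1=NC(c2ccc(Cl)cc2)C(c2ccc(Cl)cc2)N1C(=O)N1CCN(CCCCCC(=O)NO)CC1` gives 170 nM, compound 2 `CCOc1cc(C(C)(C)C)ccc1C1=NC(c2ccc(Cl)cc2)C(c2ccc(Cl)cc2)N1C(=O)NCCCCCCCC(=O)NO` gives 340 nM and compound 3 `CCOc1cc(C(C)(C)C)ccc1C1=NC(c2ccc(Cl)cc2)C(c2ccc(Cl)cc2)N1C(=O)NCc1ccc(C(=O)NO)cc1` gives 580 nM. Compound 2 thus has the second highest of the three numbers, with compound 1 and compound 3 each within the scatter of it. Compound 4 `CCOc1cc(C(C)(C)C)ccc1C1=NC(c2ccc(Cl)cc2)C(c2ccc(Cl)cc2)N1C(=O)NCCCCCC(=O)Nc1ccccc1N` differs from compound 2 by (2-aminophenyl)carbamoyl in place of 2-(hydroxycarbamoyl)ethyl on a saturated chain carbon, five bonds along the chain from an amide-type nitrogen. For the measured compounds named here, the only measured step that bears on a change at this end of the chain is a 1.7-fold higher number from compound 2 to compound 3 (0.23 log units; within the scatter), which stayed within the scatter; the gap between compound 1 and compound 2 is likewise within the scatter. The expected step is therefore a 1.2-fold higher number from compound 2 to compound 4 (0.07 log units; within the scatter), not beyond the scatter in either direction. Compound 4 is estimated at 400 nM, with a range from 150 nM to 1100 nM.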

Compound 4, inhibition constant: 1430 nM
Compound 4: the middle estimate sits 3.6-fold (0.55 log units) below what was measured; the measured number lies above the stated range.
By their numbers in this assay, from the lowest: compounds 1, 2 and 3 (each within the scatter of the next, the first and the last beyond it); then compound 4.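

In this assay, (2-aminophenyl)carbamoyl in place of 2-(hydroxycarbamoyl)ethyl gives a 4.2-fold higher number from compound 2 to compound 4 (0.62 log units; beyond the scatter), the only step shown here that lies beyond the scatter. This end of the chain therefore does respond to what it carries, which a 1.7-fold higher number from compound 2 to compound 3 (0.23 log units; within the scatter) did not show. No supporting measurement explains this rise. The step changes the terminal group and the chain together, so their contributions cannot be separated. Going by these compounds, whether a longer chain bearing (2-aminophenyl)carbamoyl, or a carboxylic acid at this chain end, would stay within the scatter of compound 2 remains open.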